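Compound 3 to compound 4: hydroxy to methoxy

This account rests on a few compounds, and the source may have more. Where it says the series, first, only, none or still open, it means among the compounds named here.

Measured so far:
compound 1, `Cc1ccc(C2C(C#N)=C(N)N(c3ccc(S(N)(=O)=O)cc3)C3=C2C(=O)CCC3)cc1`, in a functional assay on Ehrlich cells (Mus musculus) for antiproliferative activity, read by trypan blue exclusion, with a stated time of 2 h, tested at 25 ug/mL; a lower number here means a weaker effect, a higher number a stronger effect of the compound at the concentration tested: 30%
compound 2, `N#CC1=C(N)N(c2ccc(S(N)(=O)=O)cc2)C2=C(C(=O)CCC2)C1c1ccc(Cl)cc1Cl`, in this assay: 50%
compound 3, `N#CC1=C(N)N(c2ccc(S(N)(=O)=O)cc2)C2=C(C(=O)CCC2)C1c1c(O)ccc2ccccc12`, in this assay: 0%

Compound 3 stands lowest of the three numbers in this assay. Its nearest neighbour is compound 1, with a number 30 percentage points lower from compound 1 to compound 3 (beyond the scatter); the furthest is compound 2, with a number 50 percentage points lower from compound 2 to compound 3 (beyond the scatter). Both of these steps, and also a number 20 percentage points higher from compound 1 to compound 2 (beyond the scatter), exchange the whole group on the saturated ring carbon, and none of them touches the oxygen of the 2-hydroxynaphthalen-1-yl group.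

Compound 4, `COc1ccc2ccccc2c1C1C(C#N)=C(N)N(c2ccc(S(N)(=O)=O)cc2)C2=C1C(=O)CCC2`, differs from compound 3 by methyl in place of hydrogen on an oxygen on an aromatic ring. Among the measured compounds shown here, no measured pair changes the substituent on that oxygen, so no step bears directly on this change; the three steps in hand only show that the group on the saturated ring carbon can move the read-out by modest to large amounts. With compound 3 at the bottom of the range in this assay, a small upward move or none beyond the scatter is expected, so the step of a number 10 percentage points higher from compound 3 to compound 4 (within the scatter) is estimated as small. Compound 4 is therefore expected to give about 10%, in a range from 0% to 35%.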

Compound 4, a percentage reported as activity, at one concentration (the size of the read-out at that concentration, not a potency): 62%
Estimate against measurement, compound 4: 52 percentage points below; the whole stated range lies below it.
By their numbers in this assay, from the lowest: compound 3; then compound 1; then compound 2; then compound 4.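

In this assay, the substituent on the oxygen on the aromatic ring proves to be a strong control point: with methyl in place of hydrogen, a change of one heavy atom, the series shows a number 62 percentage points higher from compound 3 to compound 4 (beyond the scatter), and this pair spans the full range of the four values. The 2-methoxynaphthalen-1-yl group also exceeds both groups with a single benzene ring, with a number 12 percentage points higher from compound 2 to compound 4 (beyond the scatter) and a number 32 percentage points higher from compound 1 to compound 4 (beyond the scatter), so the low read-out of compound 3 cannot be attributed to the naphthalen-1-yl part alone, since that part is shared by the lowest and the highest compound in the series. Nothing in hand explains the size of this change in the read-out.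

Going by these compounds, it remains open whether the gain depends on methyl itself or would persist with an ethyl, a longer chain, or an acetyl group on the same oxygen. On these data alone, it is also open whether a methoxy group on the phenyl ring of compound 1 or compound 2 would raise the read-out in the same way, and, with only one concentration tested, whether the stronger effect of compound 4 at that concentration would hold at other concentrations.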